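This account rests on a few compounds, and the source may have more. Where it says the series, first, only, none or still open, it means among the compounds named here.

The three measured compounds share one core and differ at two places. Compound 1 `CC[C@@H]1C(=O)N(C)c2cnc(-n3ccnc3-c3ccccc3)nc2N1[C@@H]1CCOC1` gives 21 nM in an assay on isolated protein for inhibition of serine/threonine-protein kinase PLK2 (Homo sapiens), read by TR-FRET, with a stated time of 60 min; on this read-out higher numbers stand for weaker inhibition and lower numbers for stronger inhibition. Among the measured compounds shown here, compound 2 `CC[C@@H]1C(=O)N(C)c2cnc(-n3ccnc3-c3ccccc3)nc2N1C1CCCC1` gives 5 nM in the same read-out, and the step of a 4.2-fold lower number from compound 1 to compound 2 (0.62 log units; beyond the scatter) is the only change measured on its own. Compound 3 `CC[C@@H]1C(=O)N(C)c2cnc(-n3ccnc3-c3ccc(F)cc3)nc2N1CCC(F)(F)F` gives 42 nM, the highest of the three numbers; it lies close to compound 1 and far from compound 2.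

Compound 4 `CC[C@@H]1C(=O)N(C)c2cnc(-n3ccnc3-c3ccccc3)nc2N1CCC(F)(F)F` differs from compound 3 only in the change (hydrogen in place of fluoro on an aromatic carbon), which, cut one bond further out, reads 4-fluorophenyl to phenyl. For the measured compounds named here, none of the measured steps bears on this change: the single measured step alters the group on the ring nitrogen and leaves the phenyl ring untouched. Compounds 1 and 2 carry the plain phenyl ring while compound 3 carries the 4-fluorophenyl ring, but compound 3 also bears a different group on the ring nitrogen, so those values do not isolate the fluoro. Going by the values given here, with no measured step for this change, the expected step of a 1.2-fold lower number from compound 3 to compound 4 (0.08 log units; within the scatter) for compound 4 is small, within the scatter, in either direction. Compound 4 is therefore estimated at 35 nM, with a range from 15 nM to 90 nM.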

Compound 4, half-maximal inhibitory concentration: 9 nM
The estimate for compound 4 lay 3.9-fold (0.59 log units) above the measured number; the measured number lies below the stated range.
By their numbers in this assay, from the lowest: compounds 2 and 4 (each within the scatter of the next); then compounds 1 and 3 (each within the scatter of the next).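

Taking out the fluoro is the first change to the phenyl ring that can be read on its own, and in this assay it is not neutral, giving (a 4.7-fold lower number from compound 3 to compound 4 (0.67 log units; beyond the scatter)) with 3,3,3-trifluoropropyl held on the ring nitrogen. With the plain phenyl ring held constant, 3,3,3-trifluoropropyl can also be set against the two other groups on that nitrogen: in place of oxolan-3-yl it gives (a 2.3-fold lower number from compound 1 to compound 4 (0.37 log units; beyond the scatter)), while in place of cyclopentyl it gives (a 1.8-fold higher number from compound 2 to compound 4 (0.26 log units; within the scatter)), so those two groups cannot be told apart here. No measurement at hand accounts for the size of the fluoro step.

From the compounds shown here alone, it remains open whether the fluoro step carries over to the compounds with cyclopentyl or oxolan-3-yl on the ring nitrogen, or whether it depends on the group at that nitrogen. Also open, going by these compounds, is how a chloro, methoxy or nitrile group on the same aromatic carbon, or an amine at the end of the chain on the ring nitrogen, would read in this assay on this core.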